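The source may report more compounds than this note shows. Statements on the series, on what has been measured and on what is new or still open speak of the compounds shown alone.

Compound 1 `CCOC(=O)CCCCCOc1cccc(CN(C(=O)c2ccccc2)C(C)C)c1` gives > 26000 nM in an ADME assay on BJ cells (Homo sapiens) for cytotoxicity, read by CellTiter-Glo and resazurin assay, with a stated time of 72 h (on this read-out lower numbers stand for an effect already at smaller amounts and higher numbers for an effect only at larger amounts of compound), which is a limit of the assay and not a number.
Compound 2 `CCOC(=O)CCCCCOc1cccc(CN(C(=O)c2ccc(-c3ccc4ccccc4c3)cc2)C(C)C)c1` gives > 26000 nM in this assay, again a limit rather than a number.

Compound 2 therefore stands at the edge of what the assay can report: the limit of > 26000 nM in this assay, at which 2 of the 2 values shown sit. Within the data shown here, the only measured change, a step that the two limits leave unreadable from compound 1 to compound 2, is one whose size cannot be read, since both of its ends are limits; all that can be said is that adding the naphthalen-2-yl group did not bring the measurement into the readable range.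

Compound 3 `CCOC(=O)CCCCCOc1cccc(CN(C(=O)c2ccc(-c3cccc(-c4ccccc4)c3)cc2)C(C)C)c1` is the next step, and it differs from compound 2 by 3-phenylphenyl in place of naphthalen-2-yl on an aromatic carbon. Among the measured compounds shown here, the one measured step gives no size to lean on, only the observation that a large aromatic addition at this position left compound 2 at the limit. For the measured compounds named here, with that as the sole guide, compound 3 is expected to remain at or beyond the limit too, so the estimated step that the limit leaves unreadable from compound 2 to compound 3 is taken as none beyond the scatter. Compound 3 is estimated at 40000 nM, within a range from 15000 nM to 150000 nM, and most likely the assay will again report only a limit.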

Compound 3, half-maximal effective concentration: > 26000 nM
Compound 3: only a limit was reported (the forecaster's own chance of this, stated with the estimate: 85%); the middle value lies beyond the limit too.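

Compound 3 gives > 26000 nM in this assay, again a limit and not a number, so the steps to it from compound 1 and from compound 2 cannot be read. The compounds shown leave open at what concentration any of them would affect these cells, since all three stop at the same point: the limit of > 26000 nM in this assay, at which 3 of the 3 values shown sit.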